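The source may report more compounds than this note shows. Statements on the series, on what has been measured and on what is new or still open speak of the compounds shown alone.

Measured in a functional assay on B16 cells (Mus musculus) for antiproliferative activity, read by MTT assay, with a stated time of 24 h; a higher number here means a weaker inhibitor, a lower number a stronger inhibitor:
Compound 1 `COc1cccc(C(=O)Oc2ccc3c(=O)c(-c4cc(OC)c(OC)cc4OC)coc3c2)c1`: > 10000 nM, a limit of the assay
Compound 2 `COc1cc(OC)c(-c2coc3cc(OCc4ccc(F)cc4)ccc3c2=O)cc1OC`: 1120 nM

For the measured compounds named here, compound 2 is the only compound here with a real number, since the other value is a limit. Compound 3 `COc1cc(OC)c(-c2coc3cc(OCc4ccc(Br)cc4)ccc3c2=O)cc1OC` differs from it by bromo in place of fluoro on an aromatic carbon, with bromo in place of fluoro on an aromatic carbon, para to a large group. Going by the values given here, the sole measured step, an at least 8.9-fold lower number from compound 1 to compound 2 (0.95 log units; beyond the scatter), replaced an entire group on the oxygen and did not vary this halogen, so it offers little guide to size. No shift beyond the scatter is therefore expected in this assay, and no direction is favoured. The expected change is a 1.1-fold lower number from compound 2 to compound 3 (0.05 log units; within the scatter). For compound 3 the estimate is 1000 nM, within an expected range of 350 nM to 3500 nM.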

Compound 3, half-maximal inhibitory concentration: 1180 nM
Compound 3: the middle estimate sits 1.2-fold (0.07 log units) below what was measured; measured number inside the range.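

In this assay, bromo in place of fluoro on the aromatic carbon gives a 1.1-fold higher number from compound 2 to compound 3 (0.02 log units; within the scatter), so this position does not tell these two halogens apart. With 4-bromobenzyl on the oxygen there is still an at least 8.4-fold lower number from compound 1 to compound 3 (0.92 log units; beyond the scatter), so this step does not depend on the fluoro. Compound 1 stands only as a limit of the assay, not a number: the limit of > 10000 nM in this assay, at which 1 of the 3 values shown sits.

Still open, on these data alone, is whether an amine or a carboxylic acid on this aromatic carbon would shift the number beyond the scatter. Also open, as far as these compounds go, is what a longer chain in place of the benzyl group would do.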